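Changing the aryl group on a weak cell-growth inhibitor

This account rests on a few compounds, and the source may have more. Where it says the series, first, only, none or still open, it means among the compounds named here.

Compound 1, `COc1cc2c(Oc3ccc(NC(=O)c4nn(-c5ccccc5C)cc(C)c4=O)cc3)ccnc2cc1OCCCCCC(=O)NO`: 1830 nM
Compound 2, `COc1cc2c(Oc3ccc(NC(=O)c4nn(-c5ccccc5C)ccc4=O)c(F)c3)ccnc2cc1OCCCCCCC(=O)NO`: 3650 nM
Compound 3, `COc1cc2c(Oc3ccc(NC(=O)c4nn(-c5ccccc5C)cc(C)c4=O)cc3)ccnc2cc1OCC(=O)NO`: 8780 nM

In a functional assay on MCF7 cells (Homo sapiens) for inhibition, read by MTT assay, with a stated time of 72 h (a lower number here means a stronger inhibitor, a higher number a weaker inhibitor), compound 3 gives 8780 nM, the highest number of the three, so of the compounds measured it is the weakest inhibitor. Compound 2 at 3650 nM is its nearest neighbour, and compound 1 at 1830 nM lies furthest from it. Within the data shown here, the only single change that has been measured put hydroxycarbamoyl in place of 4-(hydroxycarbamoyl)butyl on a saturated chain carbon bound to an oxygen on an aromatic ring and gave a 4.8-fold higher number from compound 1 to compound 3 (0.68 log units; beyond the scatter).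

Compound 4, `COc1cc2c(Oc3ccc(NC(=O)c4nn(-c5ccc(Cl)c(C(F)(F)F)c5)cc(C)c4=O)cc3)ccnc2cc1OCC(=O)NO`, keeps the short chain of compound 3 and differs from it only at the aromatic nitrogen: 4-chloro-3-(trifluoromethyl)phenyl in place of 2-methylphenyl on an aromatic nitrogen. Among the measured compounds shown here, no measured pair varies this group, so the one measured step has no bearing on this change, and neither the direction nor the size of its effect can be read from the numbers. The expectation is therefore a step within the scatter, a 1.0-fold higher number from compound 3 to compound 4 (0.00 log units; within the scatter), with a wide range around it. Compound 4 is expected to give about 8800 nM, somewhere between 3000 nM and 26000 nM.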

Compound 4, half-maximal inhibitory concentration: 3480 nM
Beside the measured number, compound 4's estimate is 2.5-fold (0.40 log units) above it; the range from low to high includes it.
By their numbers in this assay, from the lowest: compounds 1, 4 and 2 (each within the scatter of the next); then compound 3.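

Among these compounds, this is the first measured change to the aryl group on the aromatic nitrogen, and in this assay the swap gives a 2.5-fold lower number from compound 3 to compound 4 (0.40 log units; beyond the scatter). The position can therefore shift the cell result on its own, with the short chain and the rest of the molecule held the same. The entering 4-chloro-3-(trifluoromethyl)phenyl carries more heavy atoms than 2-methylphenyl, including chlorine and fluorine, and still gives a stronger inhibitor in this single pair, though no available evidence bears on why the number falls.

The compounds shown leave open whether the chloro group, the trifluoromethyl group or the loss of the methyl group accounts for the step, since all of these change together in one swap. They also leave open whether the same swap would give a similar step on the 4-(hydroxycarbamoyl)butyl chain of compound 1, and how a simpler ring substituent such as a lone fluorine, a methoxy group or an amine would behave at this position.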